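Swapping a hydroxyl tail for a diethylamino tail

The source may report more compounds than this note shows. Statements on the series, on what has been measured and on what is new or still open speak of the compounds shown alone.

Measured so far in a physicochemical assay for solubility, read by HPLC, in phosphate buffer, at pH 6.5; on this read-out lower numbers stand for lower solubility and higher numbers for higher solubility:
- compound 1, `COCCCNc1nnc(-c2ccc(F)c(F)c2Nc2ccc(I)cc2F)o1`: compound 1 gives < 3 ug/mL
- compound 2, `OCCCCCNc1nnc(-c2ccc(F)c(F)c2Nc2ccc(I)cc2F)o1`: compound 2 gives < 3 ug/mL

Both of these values are limits of this assay, not numbers. Compound 2 therefore stands at the limit of < 3 ug/mL in this assay, at which 2 of the 2 values shown sit; the true solubility of compound 2 is somewhere under that limit, and how far under cannot be told.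

Compound 3, `CCN(CC)CCCNc1nnc(-c2ccc(F)c(F)c2Nc2ccc(I)cc2F)o1`, is not yet measured. It differs from compound 2 in one place: diethylamino in place of 2-hydroxyethyl on a saturated chain carbon, three bonds along the chain from a nitrogen on an aromatic ring.

Only one measured step exists among the compounds shown, a step that the two limits leave unreadable from compound 1 to compound 2. Since both ends of that step are limits, its size stays hidden, and it says nothing about how a change of this kind moves solubility. Among the compounds with values here, no step bearing on the exchange of a hydroxyl-bearing chain for a diethylamino-bearing chain has been measured here.

In the absence of any readable step, the expectation for compound 3 rests only on the change itself and is held loosely: compound 3 is estimated to come out at 15 ug/mL, between 3 ug/mL and 100 ug/mL, which would mean an expected step of an at least 5.0-fold higher number from compound 2 to compound 3 (0.69 log units; beyond the scatter) in this assay.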

Compound 3, solubility: < 3 ug/mL
Compound 3: only a limit was reported (the forecaster's own chance of this, stated with the estimate: 35%); middle value at least 5.0-fold (0.69 log units) from the limit.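

No step can be read among compound 1, compound 2 and compound 3 in this assay, since all three values are limits and not numbers: the limit of < 3 ug/mL in this assay, at which 3 of the 3 values shown sit.

As far as these compounds go, what stays open is how far under that limit each compound truly lies, and so whether diethylamino in place of 2-hydroxyethyl changes the read-out at all.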